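Swapping the aryl group on the ring nitrogen of a dihydropyridine

The source may report more compounds than this note shows. Statements on the series, on what has been measured and on what is new or still open speak of the compounds shown alone.

Compound 1 `CCOC(=O)C1=C(C)N(c2ccc(F)cc2)C=CC1c1ccccc1`: -10.9%
Compound 2 `COC(=O)C1=C(C)N(c2ccc(OC)cc2)C=C(C)C1c1ccccc1`: -13.9%

In a functional assay, tested at 100 ug/mL (on this read-out lower numbers stand for a stronger effect and higher numbers for a weaker effect at the one concentration tested), compound 1 gives -10.9%, and compound 2 gives -13.9%. These two numbers lie within the usual scatter of each other, so compound 2 stands alongside compound 1 rather than apart from it. Compound 3 `COC(=O)C1=C(C)N(c2cccc(C)c2C)C=C(C)C1c1ccccc1` differs from compound 2 in one place: 2,3-dimethylphenyl in place of 4-methoxyphenyl on an amine nitrogen in a ring. Among the compounds with values here, no step between measured compounds shows how this read-out answers such a change. The step from compound 2 to compound 3 is expected to be a number 5.9 percentage points higher from compound 2 to compound 3 (within the scatter), none beyond the scatter. Compound 3 is estimated at -8%, with a range from -30% to 15%.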

Compound 3, a percentage reported as activity, at one concentration (the size of the read-out at that concentration, not a potency): -19.7%
Estimate against measurement, compound 3: 11.7 percentage points above; the measured number falls inside the stated range.
By their numbers in this assay, from the lowest: compounds 3, 2 and 1 (each within the scatter of the next).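

In this assay, putting 2,3-dimethylphenyl in place of 4-methoxyphenyl on an amine nitrogen in a ring gives a number 5.8 percentage points lower from compound 2 to compound 3 (within the scatter). This read-out therefore does not separate the two aryl groups, even though the entering group lacks the hydrogen-bond acceptor of 4-methoxyphenyl. No measurement here offers an explanation for this result.

Going by these compounds, it remains open whether a group of another kind on this nitrogen, such as a longer alkyl chain, or an aryl ring carrying a carboxylic acid or an amine, would give a step beyond the scatter.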